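Cyclopropyl to isopropyl on the nitrogen-bound chain carbon

A few compounds are considered here, and "the series" means these few. Any claim that something is new, unique, unknown or untested is made for them only; others in the source may bear on it.

Measured compounds:
compound 1 `COc1cc(N(CC2CC2)c2ccc(F)c3ccccc23)cnc1C(=O)[C@H]1C[C@@H]1C(=O)O` — 5.4 uL/min
compound 2 `COc1cc(N(CC(C)C)c2ccc(F)c3ccccc23)cnc1C(=O)[C@H]1C[C@@H]1C(=O)O` — 56 uL/min
compound 3 `COc1cc(N(CC2CC2)c2cccc(C(F)(F)F)c2)cnc1C(=O)[C@H]1C[C@@H]1C(=O)O` — 2.3 uL/min

All three were run in an ADME assay on cells (Hepatocyte, Homo sapiens) for metabolic stability, read by LC-MS, with a stated time of 60 min, tested at 1 uM; a higher number here means faster removal of the compound, a lower number slower removal. In this assay compound 1 gives 5.4 uL/min and compound 2 gives 56 uL/min. The two differ in one place, (isopropyl in place of cyclopropyl on a saturated chain carbon bound to a nitrogen on an aromatic ring), and the step is a 10-fold higher number from compound 1 to compound 2 (1.02 log units; beyond the scatter).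

Compound 3 shares the right-hand part of compound 1 but carries a different core; the difference between the two cores is not broken down here. In this assay compound 3 gives 2.3 uL/min, the lowest of the three numbers, and both its gaps, to compound 1 and to compound 2, lie beyond the usual scatter.

Compound 4 `COc1cc(N(CC(C)C)c2cccc(C(F)(F)F)c2)cnc1C(=O)[C@H]1C[C@@H]1C(=O)O` has not yet been measured. It differs from compound 3 by isopropyl in place of cyclopropyl on a saturated chain carbon bound to a nitrogen on an aromatic ring. The place is described in the same words as for the pair of compound 1 and compound 2, so this is the same change, made on the core of compound 3 instead of the core of compound 1. Among the compounds shown it occurs only in that pair and in this one, so the expectation rests on a single measured step.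

Among the compounds with values here, for compound 4 the expected step is an 8.7-fold higher number from compound 3 to compound 4 (0.94 log units; beyond the scatter), set beside the measured 10-fold higher number from compound 1 to compound 2 (1.02 log units; beyond the scatter), with the range widened for the single precedent and the change of core. On that basis compound 4 is estimated at 20 uL/min, between 8 uL/min and 50 uL/min.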

Compound 4, intrinsic clearance in a liver preparation (reported as CLH), per the amount of preparation that the assay uses: 2.9 uL/min
Estimate against measurement, compound 4: 6.9-fold (0.84 log units) above; measured number below the stated range.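

Carried to the second core, the change gives a 1.3-fold higher number from compound 3 to compound 4 (0.10 log units; within the scatter) in this assay, so on this core isopropyl and cyclopropyl at this place cannot be told apart. The size of the step therefore depends on the core it is made on: the same change on two cores in this assay, a 10-fold higher number (1.02 log units; beyond the scatter) from compound 1 to compound 2 and a 1.3-fold higher number (0.10 log units; within the scatter) from compound 3 to compound 4, 8.2-fold (0.92 log units) apart, beyond the scatter of two such steps

The large step on the core of compound 1 cannot be treated as a fixed increment to be added across this series, but with a single pair on each core, the data do not show which part of the cores accounts for the difference, or why the change registers on one core and not on the other.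

Whether a third core would behave like the core of compound 1 or the core of compound 3 remains open, since the two cores differ as wholes and no compound shown separates their parts. Also open, on these data alone, is how either core would respond to other groups on a saturated chain carbon bound to a nitrogen on an aromatic ring, such as a longer chain or a chain ending in an amine.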